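The compounds below may be only part of what the source reports. "The series", "measured", "known", "first", "only" and "open" are said of these compounds alone.

Three measured compounds share one core and differ only in the group attached on a saturated chain carbon bound to an aromatic nitrogen. Compound 1 `CNC(=O)c1cc(C(=O)NC2CC2)cn(CC2CCCOC2)c1=O` carries an oxan-3-yl group there, compound 2 `CNC(=O)c1cc(C(=O)NC2CC2)cn(Cc2cccc3[nH]ncc23)c1=O` a 1H-indazol-4-yl group, and compound 3 `CNC(=O)c1cc(C(=O)NC2CC2)cn(Cc2cccc(C)c2)c1=O` a 3-methylphenyl group. The read-out is a physicochemical assay for solubility; on this read-out higher numbers stand for higher solubility and lower numbers for lower solubility. For compound 1 the result is only a limit of the assay, >= 131 ug/mL. Compound 2 gives 10 ug/mL, and so the change from the oxan-3-yl group to the indazole is an at least 13-fold lower number from compound 1 to compound 2 (1.11 log units; beyond the scatter). For compound 3 the result is again a limit of the assay, >= 205 ug/mL. Against compound 2 this reads as an at least 20-fold higher number from compound 2 to compound 3 (1.31 log units; beyond the scatter), while the comparison from compound 1 to compound 3 is a step that the two limits leave unreadable from compound 1 to compound 3. Compound 3 therefore sits at the upper edge of what is shown, as the two limits the limit of >= 131 ug/mL in this assay, at which 1 of the 3 values shown sits, and the limit of >= 205 ug/mL in this assay, at which 1 of the 3 values shown sits, mark.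

Compound 4 `CNC(=O)c1cc(C(=O)NC2CC2)cn(Cc2ccccc2F)c1=O` is the next step: 2-fluorophenyl in place of 3-methylphenyl on a saturated chain carbon bound to an aromatic nitrogen. Neither measured step swaps one six-membered carbon-only aromatic ring for another, so none bears directly on this change; the large steps involve the indazole. For compound 4 the expected step is an at least 1.1-fold lower number from compound 3 to compound 4 (0.05 log units; that floor lies within the scatter), that is, nothing beyond the scatter. The estimate for compound 4 is 180 ug/mL, within a range of 80 ug/mL to 350 ug/mL.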

Compound 4, solubility: >= 145 ug/mL
Compound 4: a limit, no number; the forecaster's own chance of this, stated with the estimate: 50%; the middle value is on the limit's open side.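

The result for compound 4 in this assay is again a limit of the assay and not a number: the limit of >= 145 ug/mL in this assay, at which 1 of the 4 values shown sits. Even so, a second group with one six-membered aromatic ring of carbon only, here 2-fluorophenyl, stands well clear of the indazole, with an at least 14-fold higher number from compound 2 to compound 4 (1.16 log units; beyond the scatter), so among the four compounds the indazole of compound 2 remains the only group that gives a measured number rather than a limit. The steps from compound 3 to compound 4 and from compound 1 to compound 4 cannot be read, as both ends of each are limits, so no order can be given among the oxan-3-yl, 3-methylphenyl and 2-fluorophenyl groups.

Going by these compounds, how far compound 1, compound 3 and compound 4 really lie past their limits stays open, and with it whether 2-fluorophenyl in place of 3-methylphenyl changes the read-out at all. Also open, on these data alone, is what an amine or a carboxylic acid would give on a saturated chain carbon bound to an aromatic nitrogen, and whether such a group would fall towards compound 2 at 10 ug/mL.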